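This account rests on a few compounds, and the source may have more. Where it says the series, first, only, none or still open, it means among the compounds named here.

Measured compounds:
compound 2 `CCC(=O)N1N=C(c2cc3ccccc3oc2=O)CC1c1ccccc1`: 9610 nM
compound 1 `CC(=O)Oc1ccccc1C1CC(C)=NN1C(=O)CN(C(C)C)C(C)C`: 34100 nM

In a functional assay on HepG2 cells (Homo sapiens) for cytotoxicity, read by MTT assay, with a stated time of 48 h (on this read-out lower numbers stand for stronger inhibition and higher numbers for weaker inhibition), compound 2 holds the lowest of the two numbers, and in this assay compound 1 gives the higher number, a gap that is beyond the scatter. The two cores differ, so this comparison guides nothing about the step to compound 3 `CC1CCCN(CC(=O)N2N=C(c3cc4ccccc4oc3=O)CC2c2ccccc2)C1`, which differs from compound 2 in one place: 3-methylpiperidin-1-yl in place of methyl on a saturated chain carbon bound to a carbonyl carbon. For the measured compounds named here, no measured pair shows this change, so the expected step of a 1.2-fold higher number from compound 2 to compound 3 (0.10 log units; within the scatter) is small, with a slightly higher number if any. Compound 3 is estimated at 12000 nM, within 4000 nM to 40000 nM.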

Compound 3, half-maximal inhibitory concentration: "not active" (no number reported)
Compound 3: no number reported; no gap can be computed for the estimate.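

For the compounds shown here, compound 3 is reported as not active in this assay without a number, so no step from compound 2 to compound 3 can be read. No evidence at hand bears on this result. The compounds shown leave open how far 3-methylpiperidin-1-yl in place of methyl moves the number.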